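This account rests on a few compounds, and the source may have more. Where it says the series, first, only, none or still open, it means among the compounds named here.

In a functional assay on the whole organism for antagonist activity, with Mus musculus as the target (a lower number here means that less compound is needed, a higher number that more compound is needed for the effect), compound 1 (`CCC(=O)N(c1ccc(F)cc1)C1CCCC1N(C)C`) gives 0.08 mg/kg and compound 2 (`CCC(=O)N(c1ccc(C(F)(F)F)cc1)C1CCCC1N(C)C`) gives 25 mg/kg as the higher of the two numbers. The next structure is compound 3 (`CCC(=O)N(c1ccc([N+](=O)[O-])cc1)C1CCCC1N(C)C`) with nitro in place of trifluoromethyl on an aromatic carbon para to a large group. Among the compounds with values here, one measured step bears on this place. With trifluoromethyl in place of fluoro the series shows a 310-fold higher number from compound 1 to compound 2 (2.49 log units; beyond the scatter) and this large step lies beyond the scatter. Within the data shown here, no measured compound carries nitro, so the size of the coming step remains uncertain. Compound 2 stands at the top of a span reaching down to compound 1 at 0.08 mg/kg and that leaves room for a fall. A moderate step is expected, covering only part of that span. The expected step is a 5.0-fold lower number from compound 2 to compound 3 (0.70 log units; beyond the scatter) in this assay toward a lower number. For compound 3 the estimated value is 5 mg/kg with an expected range from 0.5 mg/kg to 50 mg/kg in this series.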

Compound 3, dose for half-maximal effect: 6 mg/kg
Estimate against measurement, compound 3: 1.2-fold (0.08 log units) below; the measured number falls inside the stated range.
By their numbers in this assay, from the lowest: compound 1; then compound 3; then compound 2.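

In this assay nitro gives a 4.2-fold lower number from compound 2 to compound 3 (0.62 log units; beyond the scatter) and so shows that the high number of compound 2 is not shared by every group replacing fluoro on this aromatic carbon. Fluoro still holds the lowest number of the three: nitro brings a 75-fold higher number from compound 1 to compound 3 (1.88 log units; beyond the scatter) and thus recovers only a small part of the loss seen with trifluoromethyl. No measured property of these groups is at hand to account for this order.

From the compounds shown here alone, whether any other group can match fluoro here stays open; chloro, methoxy, nitrile or a plain hydrogen on this carbon would show whether the low number belongs to fluoro alone. Going by these compounds, it is also open whether the order of these three groups would hold with a longer chain on the amide carbonyl in place of the present one.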